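The source may report more compounds than this note shows. Statements on the series, on what has been measured and on what is new or still open speak of the compounds shown alone.

The set shares one core, seen in `CCC1C(=O)N(C)c2cnc(Nc3ccc(S(=O)(=O)NCCCO)cc3)nc2N1c1ccn(C)n1` for compound 1 and `CCC1C(=O)N(C)c2cnc(Nc3ccc(S(=O)(=O)NCCO)cc3)nc2N1c1ccn(C)n1` for compound 2, while compound 3, `CC[C@@H]1C(=O)N(C)c2cnc(-n3ccc4cc(C(=O)NCC(C)C)ccc43)nc2N1C1CCCC1`, carries a different arrangement on that core. In a functional assay on A549 cells (Homo sapiens) for antiproliferative activity, read by CCK-8 assay, with a stated time of 72 h (on this read-out lower numbers stand for stronger inhibition of growth and higher numbers for weaker inhibition of growth), compound 1 gives 48900 nM, and compound 3 gives 1730 nM. Compound 2 has no single number in this assay; compound 2 is recorded as "not active" (no number reported), so it stands at the weak end of the set, with no figure that can be set against compound 1. Compound 4, `CCC1C(=O)N(C)c2cnc(Nc3ccc(S(=O)(=O)NC)cc3)nc2N1c1ccn(C)n1`, differs from compound 2 by one change: hydrogen in place of hydroxymethyl on a saturated chain carbon bound to a sulfonamide nitrogen. Within the data shown here, no measured pair of this kind exists, so the size of the step in this assay cannot be read from the data; since compound 1 sits at 48900 nM and compound 2 is reported inactive, any step is expected to be small, within the scatter or modestly toward weaker inhibition. Compound 4 is therefore expected to give about 50000 nM, with a range from 15000 nM to 150000 nM, and a fair chance that only a limit is reported.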

Compound 4, concentration for 50% growth inhibition: 12600 nM
The estimate for compound 4 lay 4.0-fold (0.60 log units) above the measured number, outside the stated range (below it).
By their numbers in this assay, from the lowest: compound 3; then compound 4; then compound 1.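

In this assay hydrogen in place of 2-hydroxyethyl on a saturated chain carbon bound to a sulfonamide nitrogen gives a 3.9-fold lower number from compound 1 to compound 4 (0.59 log units; beyond the scatter) and so shows that this place affects growth inhibition by a modest amount beyond the scatter. Compound 4 also has a number where compound 2, with hydroxymethyl in place of hydrogen at that carbon, is recorded as not active, so that step cannot be read as a size. Chain length alone does not order these compounds: compound 2, with the shorter chain of the two hydroxyl-bearing compounds, goes against a steady gain on shortening, since compound 1 still has a number.

The compounds shown leave open how an amine, a carboxylic acid or a longer plain carbon chain at this place would compare with compound 4. Nothing shown explains the effect of this change.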